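The source may hold more compounds than are shown below. What is called first, only, known or untested is meant among the compounds shown, and "the series" means these compounds.

Compound 1 `COC(=O)c1nc(C)n(-c2ccc(F)cc2)n1` and compound 2 `COC(=O)c1nc(C(C)C)n(-c2ccc(F)cc2)n1` share one core and differ only in the group on an aromatic carbon of the five-membered ring. In a functional assay on NPC-TW01 cells (Homo sapiens) for inhibition, read by MTT assay, with a stated time of 72 h (on this read-out higher numbers stand for weaker inhibition of growth and lower numbers for stronger inhibition of growth), compound 1 gives 15200 nM. Compound 2 reaches only a limit of this assay, > 100000 nM, so no number is known for it; this is the limit of > 100000 nM in this assay, at which 1 of the 2 values shown sits. Among the measured compounds shown here, the one measured step, an at least 6.5-fold higher number from compound 1 to compound 2 (0.81 log units; beyond the scatter), thus points from the smaller to the larger group. Compound 3 `COC(=O)c1nc(C2CC2)n(-c2ccc(F)cc2)n1` carries the change (cyclopropyl in place of isopropyl on an aromatic carbon). For the measured compounds named here, only that single step bears on it, and it leaves compound 3 between two points: the number of compound 1 and the limit of compound 2. Compound 3 is therefore estimated at 50000 nM, with a range from 15000 nM to 200000 nM. The expected step of an at least 2.0-fold lower number from compound 2 to compound 3 (0.30 log units; that floor lies within the scatter) is modest, in the direction of stronger growth inhibition, though a limit is again quite possible.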

Compound 3, concentration for 50% growth inhibition: 95900 nM
Compound 3: the middle estimate sits 1.9-fold (0.28 log units) below what was measured; the range from low to high includes it.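

In this assay, cyclopropyl in place of methyl on this aromatic carbon gives a 6.3-fold higher number from compound 1 to compound 3 (0.80 log units; beyond the scatter), so both replacements of methyl shown here, isopropyl and cyclopropyl, weaken growth inhibition, and neither compound goes against that pattern. Tying the three carbons of isopropyl into a cyclopropyl ring gives an at least 1.0-fold lower number from compound 2 to compound 3 (0.01 log units; that floor lies within the scatter), so the ring does not bring back the level of compound 1. How far compound 3 truly lies from compound 2 stays unknown because compound 2 reaches only a limit: the limit of > 100000 nM in this assay, at which 1 of the 3 values shown sits.

The compounds shown leave open how a hydrogen, an amine or a hydroxymethyl group on this carbon would compare with methyl. They also leave open what a carboxylic acid in place of the methoxycarbonyl group would do to growth inhibition.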